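Amino versus alkylamino on the deoxyribose-bearing core

This account rests on a few compounds, and the source may have more. Where it says the series, first, only, none or still open, it means among the compounds named here.

Compound 3 `Nc1nc(Br)nc2c1ncn2[C@@H]1C[C@@H](O)[C@H](CO)O1` carries a free amino group and a bromine on the shared core. Among the compounds with values here, in a functional assay on K562 cells (Homo sapiens) (a lower number here means a stronger inhibitor, a higher number a weaker inhibitor), compound 3 gives 83 uM, the only finite number in the set. Compound 2 `CN(C)c1nc(Br)nc2c1ncn2[C@@H]1C[C@@H](O)[C@H](CO)O1` is the dimethylamino counterpart of compound 3; in this assay compound 2 reaches only > 300 uM, which is a limit rather than a number. Compound 1 `CNc1nc(SC)nc2c1ncn2[C@@H]1C[C@@H](O)[C@H](CO)O1`, with a methylamino group and a methylthio group in place of bromine, likewise reaches only a limit, > 300 uM. Both limits coincide with the limit of > 300 uM in this assay, at which 2 of the 3 values shown sit.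

Within the data shown here, the one measured step that bears on the change under consideration is an at least 3.6-fold lower number from compound 2 to compound 3 (0.55 log units; beyond the scatter): removing both methyl groups from the exocyclic nitrogen gave the only finite value. Compound 4 `CNc1nc(Br)nc2c1ncn2[C@@H]1C[C@@H](O)[C@H](CO)O1` sits between the two, differing from compound 3 by methyl in place of hydrogen on a nitrogen on an aromatic ring, which restores one of the two methyls. On that single step, a reversal toward weaker inhibition is expected, of smaller size than the whole dimethyl-to-amino step, though the measured direction in this assay is clear. Compound 4 is therefore expected to show a 2.4-fold higher number from compound 3 to compound 4 (0.38 log units; beyond the scatter), with a real chance of falling at the limit. The estimate for compound 4 in this assay is 200 uM, within 70 uM to 600 uM.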

Compound 4, concentration for 50% inhibition: 110 uM
Beside the measured number, compound 4's estimate is 1.8-fold (0.26 log units) above it, within the range that was stated.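

On the exocyclic nitrogen, a single methyl leaves the value in this assay essentially unchanged: a 1.3-fold higher number from compound 3 to compound 4 (0.12 log units; within the scatter), so the amino and methylamino compounds cannot be ordered. The clear separation comes only with the second methyl, an at least 2.7-fold lower number from compound 2 to compound 4 (0.43 log units; beyond the scatter), which places the break at the step from methylamino to dimethylamino rather than spreading it evenly over both methyls. With the methylamino group held constant, the group on the other aromatic carbon also matters, an at least 2.7-fold lower number from compound 1 to compound 4 (0.43 log units; beyond the scatter), and like the previous step this one starts from a limit rather than a number: the limit of > 300 uM in this assay, at which 2 of the 4 values shown sit.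

Going by these compounds, how far compound 1 and compound 2 actually lie from compound 4 stays open, since both steps give only a minimum size. Also open, on these data alone, is whether a longer chain on the nitrogen, such as ethyl or propyl, follows the methylamino or the dimethylamino result, and whether chloro or iodo in place of bromo keeps the value of compound 4.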